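This account rests on a few compounds, and the source may have more. Where it says the series, first, only, none or still open, it means among the compounds named here.

The series shares one core acylated on the amide-type nitrogen. Compound 1 `CC1(C)CC12NC(=O)N(NC(=O)c1ccc(Cl)cc1)C2=O` carries 4-chlorophenyl on the carbonyl carbon, compound 2 `CC1(C)CC12NC(=O)N(NC(=O)c1ccccc1Cl)C2=O` carries 2-chlorophenyl there. In a functional assay on the whole organism for inhibition, with Mus musculus as the target, with a stated time of 0.5 h (a lower number here means that less compound is needed, a higher number that more compound is needed for the effect), compound 1 gives 300 mg/kg. In this assay compound 2 gives 300 mg/kg, and the step of no change at the digits printed from compound 1 to compound 2 (within the scatter) shows that 2-chlorophenyl in place of 4-chlorophenyl on the carbonyl carbon leaves the dose where it was. Compound 2 therefore stands level with compound 1 at the digits shown; no other measured compound exists for comparison.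

Compound 3 `CC1(C)CC12NC(=O)N(NC(=O)c1ccc(F)cc1)C2=O` is the next member. Its difference from compound 2 is 4-fluorophenyl in place of 2-chlorophenyl on a carbonyl carbon. For the measured compounds named here, the only measured step that bears on this change is no change at the digits printed from compound 1 to compound 2 (within the scatter), a change of the chlorophenyl group on the same carbonyl carbon, and it sits within the scatter. No exchange of chlorine for fluorine has been measured in the series, so the expectation rests on that single step alone. The expected step of no change at the digits printed from compound 2 to compound 3 (within the scatter) is accordingly none beyond the scatter. Compound 3 is expected to give 300 mg/kg in this assay, with a range from 150 mg/kg to 600 mg/kg, because compound 2 gives 300 mg/kg and its neighbour compound 1 gives 300 mg/kg.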

Compound 3, minimum effective dose: 300 mg/kg
Compound 3: the middle estimate sits on the measured number at the digits printed; the measured number falls inside the stated range.
By their numbers in this assay, from the lowest: compounds 1, 2 and 3 (each within the scatter of the next).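

The step of no change at the digits printed from compound 2 to compound 3 (within the scatter) puts 4-fluorophenyl on the carbonyl carbon at the same level as 2-chlorophenyl in this assay and extends the set of groups at this position that cannot be told apart by dose to three. The step of no change at the digits printed from compound 1 to compound 3 (within the scatter) adds what the earlier pair could not show: where that pair moved the chlorine on the phenyl ring, this one exchanges the halogen itself, fluoro in place of chloro on an aromatic carbon, and the read-out again does not separate the two compounds. Nothing at hand explains why the dose stays level across these groups.

Going by these compounds, all three groups are halogen-bearing phenyl rings, so it remains open whether the same level holds for unsubstituted phenyl, for a phenyl carrying an amine or a carboxylic acid, or for a longer alkyl chain on the carbonyl carbon. On these data alone, the shared core is also the same in all three compounds, and whether any change, at this position or on the core, can move the dose in this assay remains unknown.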